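The source may hold more compounds than are shown below. What is called first, only, known or untested is meant among the compounds shown, and "the series" means these compounds.

Compound 2 `Cn1cc(-c2nn(Cc3ccc(C(=O)N4CCCCC4)cc3)c(=O)c3ccccc23)cn1` sits near the top of the numbers gathered in a functional assay on A549 cells (Homo sapiens) for antiproliferative activity, read by MTT assay, with a stated time of 72 h (on this read-out lower numbers stand for stronger inhibition and higher numbers for weaker inhibition), so far. In this assay compound 2 gives 67400 nM. Compound 1 `Cc1noc(C)c1-c1nn(Cc2ccc(C(=O)NC3CC(C)(C)N([O])C(C)(C)C3)cc2)c(=O)c2ccccc12` gives 84300 nM in this assay, a number within the scatter of compound 2, so nothing separates them. Compound 3 `CC(=O)Nc1ccc(Sc2nc(Nc3cc(C)[nH]n3)cc(N3CCN(C)CC3)n2)cc1`, built on a different core, gives 15300 nM in this assay, a number beyond the scatter and lower than that of compound 2.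

Compound 4 `CN1CCC(NC(=O)c2ccc(Cn3nc(-c4cnn(C)c4)c4ccccc4c3=O)cc2)CC1` keeps the core of compound 2 and changes one group on a carbonyl carbon whose other neighbours are an aromatic carbon: (1-methylpiperidin-4-yl)amino in place of piperidin-1-yl on a carbonyl carbon. The entering (1-methylpiperidin-4-yl)amino brings one hydrogen-bond donor and one hydrogen-bond acceptor where the leaving piperidin-1-yl had none. Compound 1 carries a related carbamoyl arrangement and sits at a similarly weak level, so compound 4 is expected to stay in the weak range, with a step of a 1.2-fold lower number from compound 2 to compound 4 (0.09 log units; within the scatter) that is expected not to exceed the scatter. Compound 4 is estimated at 55000 nM, within 15000 nM to 150000 nM.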

Compound 4, half-maximal inhibitory concentration: 54300 nM
Compound 4: middle estimate off by 1.0-fold (0.01 log units), on the high side; measured number inside the range.
By their numbers in this assay, from the lowest: compound 3; then compounds 4, 2 and 1 (each within the scatter of the next).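

On a carbonyl carbon whose other neighbours are an aromatic carbon, (1-methylpiperidin-4-yl)amino in place of piperidin-1-yl comes with a 1.2-fold lower number from compound 2 to compound 4 (0.09 log units; within the scatter) in this assay. Within the data shown here, this is the first comparison in the set between compounds that differ in one place, and it shows that the entering group, with its hydrogen-bond donor and acceptor, leaves the number unseparated from that of the leaving group. No measurement shown bears on this result.

From the compounds shown here alone, whether a carboxylic acid, a primary amine or a longer chain ending in an amine on this carbonyl carbon would separate from compound 2 remains open. With only one step at this position, the compounds shown also cannot tell whether the same lack of separation would hold for other groups here.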